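A few compounds are considered here, and "the series" means these few. Any claim that something is new, unique, unknown or untested is made for them only; others in the source may bear on it.

Compound 1 `COc1ccc([C@@H]2C/C(=N/OCc3cn(-c4ccc(C(=O)c5ccccc5)cc4)nn3)c3cc(CC=C(C)C)c(OC)cc3O2)cc1`: 41%
Compound 2 `COc1ccc([C@@H]2C/C(=N/OCc3cn(-c4ccc(C(N)=O)cc4)nn3)c3cc(CC=C(C)C)c(OC)cc3O2)cc1`: 100%
Compound 3 `COc1ccc([C@@H]2C/C(=N/OCc3cn(-c4ccc(NC(C)=O)cc4)nn3)c3cc(CC=C(C)C)c(OC)cc3O2)cc1`: 0%

In a functional assay on MCF7 cells (Homo sapiens) for inhibition, read by sulforhodamine B assay, with a stated time of 48 h, tested at 50 uM (a higher number here means more inhibition of growth at the concentration tested, a lower number less inhibition of growth), compound 3, at 0%, stands lowest of the three. Its gaps to the others are large: a number 41 percentage points lower from compound 1 to compound 3 (beyond the scatter), and a number 100 percentage points lower from compound 2 to compound 3 (beyond the scatter).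

Compound 4 `COc1ccc([C@@H]2C/C(=N/OCc3cn(-c4ccc(NC(=O)c5ccccc5)cc4)nn3)c3cc(CC=C(C)C)c(OC)cc3O2)cc1` differs from it in one place: phenyl in place of methyl on a carbonyl carbon, acetamido to benzamido. Among the measured compounds shown here, no measured step makes this exact exchange. The closest evidence is a number 59 percentage points higher from compound 1 to compound 2 (beyond the scatter), a large step in which phenyl leaves a carbonyl carbon. Compound 1, which holds that phenyl, gives 41%. With wide uncertainty, the rise is therefore expected to be moderate and is estimated as a number 20 percentage points higher from compound 3 to compound 4 (beyond the scatter). For compound 4 the estimated value is 20%, with an expected range of 0% to 60%.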

Compound 4, percent growth inhibition at one concentration: 4%
Estimate against measurement, compound 4: 16 percentage points above; the measured number falls inside the stated range.
By their numbers in this assay, from the lowest: compounds 3 and 4 (each within the scatter of the next); then compound 1; then compound 2.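

In this assay, phenyl in place of methyl on this carbonyl carbon separates the two amides no further than the usual scatter, with a number 4 percentage points higher from compound 3 to compound 4 (within the scatter). Benzamido stays far from both carbamoyl and benzoyl on the aromatic carbon, with a number 96 percentage points lower from compound 2 to compound 4 (beyond the scatter) and a number 37 percentage points lower from compound 1 to compound 4 (beyond the scatter), so among these compounds the two groups with the amide-type nitrogen give the low numbers, whichever of methyl or phenyl they carry. Nothing available explains this result. From the compounds shown here alone, whether an amine, a carboxylic acid or a longer chain in place of phenyl on this carbonyl carbon would give a number as low as those of compound 3 and compound 4 remains open.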